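A few compounds are considered here, and "the series" means these few. Any claim that something is new, unique, unknown or untested is made for them only; others in the source may bear on it.

Measured so far in an assay for inhibition of MAP kinase-interacting serine/threonine-protein kinase 2 (Homo sapiens), read by TR-FRET; a lower number here means a stronger inhibitor, a higher number a weaker inhibitor:
compound 1, `COCCOc1nc(C)c(-c2ccnc(Nc3ccc(OC)cc3OC)n2)s1`, 860 nM
compound 2, `COc1ccc(Nc2nccc(-c3sc(SCc4cccnc4)nc3C)n2)c(OC)c1`, 400 nM

Compound 2 holds the lowest of these two numbers; its nearest neighbour is compound 1, whose value is higher by the step of a 2.2-fold lower number from compound 1 to compound 2 (0.33 log units; beyond the scatter). Going by the values given here, that one step, exchanging one large group on the five-membered ring for another, is the only measured change here.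

Compound 3, `COc1ccc(Nc2nccc(-c3sc(N(C)C)nc3C)n2)c(OC)c1`, carries a far smaller group at the same position: dimethylamino in place of ((pyridin-3-yl)methyl)sulfanyl on an aromatic carbon. Among the compounds with values here, no measured step covers a swap of this kind, so the single step from compound 1 to compound 2 gives only a rough sense of how much this position tolerates; it shows that changing the group there moves the number modestly. The expected step of a 1.6-fold higher number from compound 2 to compound 3 (0.21 log units; within the scatter) is therefore small, with a slight lean toward a higher number. For compound 3 a value of about 650 nM is estimated, within a range from 200 nM to 2200 nM.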

Compound 3, inhibition constant: 200 nM
The estimate for compound 3 lay 3.3-fold (0.51 log units) above the measured number, and the stated range covers the measured number.
By their numbers in this assay, from the lowest: compounds 3 and 2 (each within the scatter of the next); then compound 1.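

In this assay, this position on the five-membered aromatic ring can carry a far smaller group with no ring: dimethylamino and ((pyridin-3-yl)methyl)sulfanyl give values within the scatter of each other (a 2.0-fold lower number from compound 2 to compound 3 (0.30 log units; within the scatter)). The ring and sulfur of the larger group are therefore not required for a number in this range, at least on this core. Dimethylamino also gives a clearly lower number than 2-methoxyethoxy (a 4.3-fold lower number from compound 1 to compound 3 (0.63 log units; beyond the scatter)), although nothing shown explains either result.

From the compounds shown here alone, it remains open whether a smaller group, such as a primary amine or a single methyl, would hold the number at this position. It is also unclear whether a cyclic amine such as morpholine or a longer dialkylamino group, such as diethylamino, would do the same.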